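Methyl-sulfinyl for methyl-sulfanyl on two triazole cores

This account rests on a few compounds, and the source may have more. Where it says the series, first, only, none or still open, it means among the compounds named here.

Measured so far:
- compound 1 `CSc1nnc(-c2cccc3ccccc23)n1C`: > 200 mg/kg
- compound 2 `Cn1c(-c2cccc3ccccc23)nnc1[S+](C)[O-]`: > 200 mg/kg
- compound 3 `CSc1nc(-c2ccccc2)n(C)n1`: > 100 mg/kg

For the measured compounds named here, all three values so far are limits of a functional assay on the whole organism for antagonist activity, with Mus musculus as the target (on this read-out higher numbers stand for an effect only at larger amounts of compound and lower numbers for an effect already at smaller amounts), and not numbers. For compound 1 the value is a limit (the limit of > 200 mg/kg in this assay, at which 2 of the 3 values shown sit). For compound 2 the value is the same kind of limit. For compound 3 the value is a limit as well (the limit of > 100 mg/kg in this assay, at which 1 of the 3 values shown sits). The step that the two limits leave unreadable from compound 1 to compound 2 is therefore not readable in size; both limits only say that no effect was seen up to the amounts tested.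

The change from compound 1 to compound 2 is a group of 3 heavy atoms (1 carbon, 1 oxygen, 1 sulfur; no ring) in place of a group of 2 heavy atoms (1 carbon, 1 sulfur; no ring), on an aromatic carbon. Compound 4 `Cn1nc([S+](C)[O-])nc1-c1ccccc1` carries the same kind of change against compound 3, namely (a group of 3 heavy atoms (1 carbon, 1 oxygen, 1 sulfur; no ring) in place of a group of 2 heavy atoms (1 carbon, 1 sulfur; no ring), on an aromatic carbon). The place is not word for word the same: in compound 2 the changed carbon is next to the ring atom that bears a methyl group and two ring bonds from the ring atom that bears a large group, whereas in compound 4 it is two ring bonds from the ring atom that bears a methyl group. How the core of compound 1 differs from the core of compound 3 is not broken down here.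

Expectation for compound 4 in this assay: since compound 3 sits at a limit of > 100 mg/kg in this assay, at which 1 of the 3 values shown sits, and the same kind of change in the other pair left compound 2 at a limit (the limit of > 200 mg/kg in this assay, at which 2 of the 3 values shown sit), the step that the limit leaves unreadable from compound 3 to compound 4 is expected to be small and unreadable. Compound 4 is accordingly estimated at 200 mg/kg, between 80 mg/kg and 600 mg/kg, most likely reported again as a limit.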

Compound 4, dose for half-maximal effect: > 200 mg/kg
Compound 4 gave a limit, no number; the forecaster's own chance of this, stated with the estimate: 85%; the middle value lies on the limit itself.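

In this assay compound 3 and compound 4 both sit at limits, not numbers, so no size can be read for the step between them, where a group of three heavy atoms replaces methylsulfanyl. The compounds shown leave open whether this replacement shifts the dose for half-maximal effect on either core, and what any compound's actual value in this assay is.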